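This account rests on a few compounds, and the source may have more. Where it says the series, first, only, none or still open, it means among the compounds named here.

Measured in a functional assay on A549 cells (Homo sapiens) for cytotoxicity, read by MTT assay, with a stated time of 72 h; a lower number here means a stronger inhibitor, a higher number a weaker inhibitor:
- compound 1 `COc1ccc(S(=O)(=O)c2nc3ccccc3nc2Nc2cccc(N)c2)cc1`: 340 nM
- compound 2 `COc1cc(Nc2nc3ccccc3nc2S(=O)(=O)c2ccc(Br)cc2)cc(OC)c1`: 15900 nM

Compound 2 holds the higher of the two numbers in this assay, and compound 1 lies lower by more than the scatter. Compound 3 `Nc1cccc(Nc2nc3ccccc3nc2S(=O)(=O)c2ccc(Br)cc2)c1` changes compound 2 in one place: 3-aminophenyl in place of 3,5-dimethoxyphenyl on a nitrogen on an aromatic ring. Compound 1 also carries 3-aminophenyl and gives 340 nM, so compound 3 is expected to land nearer that number. The expected change is a fall beyond the scatter, an 18-fold lower number from compound 2 to compound 3 (1.25 log units; beyond the scatter). Compound 3 is estimated at 900 nM, with a range of 200 nM to 4000 nM.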

Compound 3, half-maximal inhibitory concentration: 1120 nM
The estimate for compound 3 lay 1.2-fold (0.09 log units) below the measured number; measured number inside the range.
By their numbers in this assay, from the lowest: compound 1; then compound 3; then compound 2.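

In this assay, among the compounds shown here, with bromo held constant, 3-aminophenyl in place of 3,5-dimethoxyphenyl on the nitrogen gives a 14-fold lower number from compound 2 to compound 3 (1.15 log units; beyond the scatter), the first single-change reading at this position. With 3-aminophenyl held constant, bromo in place of methoxy gives a 3.3-fold higher number from compound 1 to compound 3 (0.52 log units; beyond the scatter), so the aromatic carbon bearing that substituent also affects the number, though by less. No measurement here explains either step.

Whether the two changes act independently remains open, as the methoxy partner of compound 2 is not among these compounds. As far as these compounds go, how a hydroxyl or a carboxylic acid would compare with the amine on the phenyl ring also remains open.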